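Series notes: cytotoxicity of three measured compounds, one pending

The source may report more compounds than this note shows. Statements on the series, on what has been measured and on what is new or still open speak of the compounds shown alone.

Values in an ADME assay on L02 cells (Homo sapiens) for cytotoxicity, read by MTT assay, with a stated time of 48 h; a lower number here means a stronger inhibitor, a higher number a weaker inhibitor:
compound 1 `N#Cc1ccc(Cn2cc(COc3ccc4c(=O)ccoc4c3)nn2)cc1` gives > 300000 nM, a limit of the assay.
compound 2 `O=c1ccoc2cc(OCc3cn(Cc4ccccc4Br)nn3)ccc12` gives > 300000 nM, a limit of the assay.
compound 3 `O=c1ccoc2cc(OCc3cn(Cc4ccccc4Cl)nn3)ccc12` gives > 300000 nM, a limit of the assay.

Compound 1 stands only at a limit in this assay, and all three values shown sit at the limit of > 300000 nM in this assay, at which 3 of the 3 values shown sit. The steps a step that the two limits leave unreadable from compound 1 to compound 2, a step that the two limits leave unreadable from compound 1 to compound 3 and a step that the two limits leave unreadable from compound 2 to compound 3 are therefore of unreadable size and give no direction. Compound 4 `O=c1ccoc2cc(OCc3cn(Cc4ccccc4)nn3)ccc12` differs from compound 1 by hydrogen in place of cyano on an aromatic carbon. Among the measured compounds shown here, none of the measured steps reads on this change; the only thing the measured compounds show is that every benzyl variant so far reaches the same limit. Compound 4 is accordingly expected to remain at that limit, with the step of a number no higher from compound 1 to compound 4 (the limit leaves the size open) expected to lie within the scatter. The estimate for compound 4 is 300000 nM, expected between 150000 nM and 600000 nM.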

Compound 4, half-maximal inhibitory concentration: > 300000 nM
Compound 4: no number, only a limit; the forecaster's own chance of this, stated with the estimate: 85%; the middle value lies on the limit itself.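

In this assay compound 4 gives > 300000 nM, a limit of the assay, so its steps to compound 1, compound 2 and compound 3 cannot be read. Whether these four compounds differ at all in this assay stays open: the limit of > 300000 nM in this assay, at which 4 of the 4 values shown sit.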